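The compounds below may be only part of what the source reports. "The series", "measured", "known", "first", "only" and "open" are said of these compounds alone.

Measured so far:
compound 1 `COc1ccc(Nc2nc(-c3cccc(F)c3)nc3ccc(F)cc23)cc1` — 41100 nM
compound 2 `Fc1ccc(Nc2nc(-c3cccc(F)c3)nc3ccc(F)cc23)cc1` — > 50000 nM

Within the data shown here, in a functional assay on U-937 cells (Homo sapiens) for cytotoxicity, read by MTT assay, with a stated time of 48 h (on this read-out higher numbers stand for weaker inhibition and lower numbers for stronger inhibition), compound 1 gives 41100 nM, the only number. Compound 2 returns > 50000 nM, which is a limit of > 50000 nM in this assay, at which 1 of the 2 values shown sits, rather than a number. Among the measured compounds shown here, the one step, an at least 1.2-fold higher number from compound 1 to compound 2 (0.08 log units; that floor lies within the scatter), lies within the scatter and concerns a different exchange. Compound 3 `Nc1ccccc1Nc1nc(-c2cccc(F)c2)nc2ccc(F)cc12` differs from compound 1 by 2-aminophenyl in place of 4-methoxyphenyl on a nitrogen on an aromatic ring. For the measured compounds named here, no measured step touches this change, so no direction beyond the scatter is expected in this assay. Compound 3 is estimated at 40000 nM, between 15000 nM and 100000 nM, an expected step of a 1.0-fold lower number from compound 1 to compound 3 (0.01 log units; within the scatter).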

Compound 3, half-maximal inhibitory concentration: 47300 nM
For compound 3 the middle estimate is 1.2-fold (0.07 log units) below the measured one; the range from low to high includes it.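

On a nitrogen on an aromatic ring, the exchange to 2-aminophenyl brings in a hydrogen-bond donor that 4-methoxyphenyl lacks, yet this assay shows a 1.2-fold higher number from compound 1 to compound 3 (0.06 log units; within the scatter). Against the 4-fluorophenyl group the reading is an at least 1.0-fold lower number from compound 2 to compound 3 (0.02 log units; that floor lies within the scatter), so this step sets no order. Compound 2 carries a limit rather than a number: the limit of > 50000 nM in this assay, at which 1 of the 3 values shown sits.

Still open, on these data alone, is whether a carboxylic acid on the phenyl ring, or a longer chain in place of that ring on the nitrogen, would give a number beyond the scatter in this assay.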